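Substituent on the aromatic nitrogen: outlook for compound 3

A few compounds are considered here, and "the series" means these few. Any claim that something is new, unique, unknown or untested is made for them only; others in the source may bear on it.

Among the measured compounds shown here, compound 2 `Cn1cc(C(=O)c2ccn3c2CSC3c2cccnc2)c2ccc(-c3ccc(F)cc3)cc21` gives 0.09 mg/kg in a functional assay on the whole organism for inhibition, with Rattus norvegicus as the target (on this read-out lower numbers stand for an effect already at smaller amounts and higher numbers for an effect only at larger amounts of compound), and holds the lowest of the two numbers measured so far. Compound 1 `CCNC(=O)n1cc(C(=O)c2ccn3c2CSC3c2cccnc2)c2ccc(-c3ccc(F)cc3)cc21` gives 0.18 mg/kg in this assay, and the step of a 2.0-fold lower number from compound 1 to compound 2 (0.30 log units; within the scatter) lies within the scatter, so the two values do not separate. Compound 3 `CN(C)C(=O)Cn1cc(C(=O)c2ccn3c2CSC3c2cccnc2)c2ccc(-c3ccc(F)cc3)cc21` carries dimethylcarbamoyl in place of hydrogen on a saturated chain carbon bound to an aromatic nitrogen. For the measured compounds named here, the only measured step that bears on the same position is the exchange from compound 1 to compound 2, which also varies what sits on the aromatic nitrogen and was without an effect beyond the scatter. On that basis no step beyond the scatter is expected for compound 3, in either direction. For compound 3 the value in this assay is therefore estimated at 0.12 mg/kg, with a range from 0.04 mg/kg to 0.4 mg/kg, corresponding to an expected step of a 1.3-fold higher number from compound 2 to compound 3 (0.12 log units; within the scatter).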

Compound 3, dose for half-maximal effect: 0.009 mg/kg
Compound 3: middle estimate off by 13-fold (1.12 log units), on the high side, and the stated range ends above it.
By their numbers in this assay, from the lowest: compound 3; then compounds 2 and 1 (each within the scatter of the next).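

The substituent on the aromatic nitrogen can move the read-out in this assay well beyond the scatter: placing dimethylcarbamoyl on the saturated chain carbon bound to that nitrogen gives a 10-fold lower number from compound 2 to compound 3 (1.00 log units; beyond the scatter) and thus separates compound 3 from the methyl group of compound 2. Exchanging ethylcarbamoyl for (dimethylcarbamoyl)methyl gives a 20-fold lower number from compound 1 to compound 3 (1.30 log units; beyond the scatter) in the same direction, so the step within the scatter between compound 1 and compound 2 did not reveal how strongly this position can respond. Nothing available here accounts for the size of this gain.

The compounds shown leave open which part of the (dimethylcarbamoyl)methyl group is tied to the step. A carboxylic acid, a primary amide or a longer chain carrying the same dimethylcarbamoyl group would test whether the step in this assay persists.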